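Trading the Aryl Ester for a Free Acid

A few compounds are considered here, and "the series" means these few. Any claim that something is new, unique, unknown or untested is made for them only; others in the source may bear on it.

Compound 3 `COc1ccc(OC(=O)c2cn(-c3ccccc3)nc2-c2ccncc2)cc1` was tested in a functional assay on HL-60 cells (Homo sapiens) for cytotoxicity, read by MTT assay, with a stated time of 48 h; a lower number here means a stronger inhibitor, a higher number a weaker inhibitor. In that setting compound 3 gives > 100000 nM, which is a limit of the assay rather than a number. Its nearest neighbour is compound 2 `COc1ccc(OC(=O)c2cn(-c3ccccc3)nc2-c2cccnc2)cc1`; in this assay compound 2 gives > 100000 nM, again only a limit. The step that the two limits leave unreadable from compound 2 to compound 3 is therefore unreadable. Compound 1 `O=C(NCc1ccccc1)c1cn(-c2ccccc2)nc1-c1cccnc1` has no result; in this assay compound 1 gives "nd(insoluble)" (no result reported). Compound 4 `O=C(O)c1cn(-c2ccccc2)nc1-c1ccncc1` differs from compound 3 by hydrogen in place of 4-methoxyphenyl on an oxygen next to a carbonyl group. Going by the values given here, no measured step covers this change, and the limit of > 100000 nM in this assay, at which 2 of the 3 values shown sit, shows most of what is known sitting at the limit. Compound 4 is therefore expected to stay there too, so the estimated step of a number no higher from compound 3 to compound 4 (the limit leaves the size open) is expected to be none beyond the scatter. The estimate for compound 4 is 100000 nM, ranging from 30000 nM to 300000 nM.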

Compound 4, half-maximal inhibitory concentration: > 100000 nM
Compound 4 was reported as a limit; the forecaster's own chance of this, stated with the estimate: 80%; the middle value lies on the limit itself.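

Compound 3 and compound 4 both stand only as limits of the assay, so no step can be read between them: the limit of > 100000 nM in this assay, at which 3 of the 4 values shown sit.

The compounds shown leave open whether any change to the shared core would give a measurable value in this assay.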